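The source may report more compounds than this note shows. Statements on the series, on what has been measured and on what is new or still open speak of the compounds shown alone.

Measured so far:
- compound 1, `CCCC(=O)NCCCc1cc(OC)ccc1OCc1ccccc1`: 0.00103 nM
- compound 2, `CCOc1ccc(OC)cc1CCCNC(C)=O`: 1.59 nM
- compound 3, `COc1ccc(OCc2ccccn2)c(CCCNC(C)=O)c1`: 1.61 nM

In an assay on CHO cells for displacement of a labelled ligand from melatonin receptor type 1B (Homo sapiens), read by scintillation counting, with a stated time of 60 min (on this read-out higher numbers stand for weaker inhibition and lower numbers for stronger inhibition), compound 2 gives 1.59 nM, the second highest of the three numbers; compound 3 sits right beside it, and compound 1 stands far below both. The unmeasured compound 4, `COc1cccc(COc2ccc(OC)cc2CCCNC(C)=O)c1`, is made from compound 2 by one change: 3-methoxyphenyl in place of methyl on a saturated chain carbon bound to an oxygen on an aromatic ring. Among the measured compounds shown here, only one measured step touches the same place, the one from compound 2 to compound 3, where a pyridin-2-yl group replaced the methyl on that same chain carbon and gave a 1.0-fold higher number from compound 2 to compound 3 (0.01 log units; within the scatter), a change that lies within the scatter. Compound 1 also carries a ring at this place, but it differs from compound 2 in a second place as well, so its very low value cannot be tied to the ring alone. For the measured compounds named here, the only clean comparison therefore points to a small step in this assay, and compound 4 is expected to land close to compound 2, with a 2.0-fold lower number from compound 2 to compound 4 (0.30 log units; within the scatter). For compound 4 the estimate is 0.8 nM, within a range from 0.08 nM to 4 nM.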

Compound 4, inhibition constant: 0.00069 nM
Estimate against measurement, compound 4: 1200-fold (3.06 log units) above; the whole stated range lies above it.
By their numbers in this assay, from the lowest: compounds 4 and 1 (each within the scatter of the next); then compounds 2 and 3 (each within the scatter of the next).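

In this assay, the saturated chain carbon bound to an oxygen on an aromatic ring proves highly sensitive to what it carries: 3-methoxyphenyl in place of methyl produces a very large change (a 2300-fold lower number from compound 2 to compound 4 (3.36 log units; beyond the scatter)). Adding a ring is not enough in itself, since pyridin-2-yl in place of methyl stays within the scatter (a 1.0-fold higher number from compound 2 to compound 3 (0.01 log units; within the scatter)), while the two ring groups stand far apart (a 2300-fold lower number from compound 3 to compound 4 (3.37 log units; beyond the scatter)). Nothing measured here explains why these two ring groups differ so much.

Whether the methoxy group is needed remains open, as a plain phenyl ring with the rest of compound 4 unchanged is not among the compounds shown. Also open, going by these compounds, is how a ring bearing an amine or a carboxylic acid would behave at this place.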